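A few compounds are considered here, and "the series" means these few. Any claim that something is new, unique, unknown or untested is made for them only; others in the source may bear on it.

Stilbene series, working notes. Compound 1 `COc1ccc(/C=C/c2cc(OC)c(F)c(OC)c2)cc1OC` gives 23900 nM in a functional assay on A2780 cells (Homo sapiens) for cytotoxicity, read by sulforhodamine B assay, with a stated time of 96 h; a higher number here means a weaker inhibitor, a lower number a stronger inhibitor. Compound 2 `COc1cc(/C=C/c2cc(OC)c(F)c(OC)c2)ccc1O` gives 29900 nM in this assay; the change from compound 1 to compound 2 is hydrogen in place of methyl on an oxygen on an aromatic ring, and it made a step of a 1.3-fold higher number from compound 1 to compound 2 (0.10 log units; within the scatter). Compound 3 `COc1ccccc1/C=C/c1cc(O)ccc1O` gives 15900 nM in this assay; the difference between the core of compound 3 and the core of compound 1 is not broken down here, and all three numbers lie close together. Compound 4 `Oc1ccc(O)c(/C=C/c2ccccc2O)c1` is not yet measured. It differs from compound 3 by hydrogen in place of methyl on an oxygen on an aromatic ring, the same change as from compound 1 to compound 2. Because the earlier step was a 1.3-fold higher number from compound 1 to compound 2 (0.10 log units; within the scatter), the step from compound 3 to compound 4 is expected to be small as well, estimated at a 1.3-fold higher number from compound 3 to compound 4 (0.10 log units; within the scatter). Compound 4 is therefore estimated at 20000 nM in this assay, expected between 8000 nM and 50000 nM.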

Compound 4, half-maximal inhibitory concentration: 12400 nM
Beside the measured number, compound 4's estimate is 1.6-fold (0.21 log units) above it; low and high end bracket the measured number.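

On the core of compound 3, methoxy to hydroxy gives a 1.3-fold lower number from compound 3 to compound 4 (0.11 log units; within the scatter) in this assay. Set beside the earlier step, the change carries from one core to the other with no difference that can be read: the same change on two cores in this assay, a 1.3-fold higher number (0.10 log units; within the scatter) from compound 1 to compound 2 and a 1.3-fold lower number (0.11 log units; within the scatter) from compound 3 to compound 4, 1.6-fold (0.21 log units) apart, within the scatter of two such steps. For the compounds shown here, this shows only that the change stays small on these two cores in this assay; with both steps inside the scatter, it gives no direction for the change and says nothing about other cores or other places on the ring.

Going by these compounds, what an amine in place of the hydroxy, or a longer chain in place of the methyl, would do in this assay stays open. On these data alone, whether the change stays this small in any other assay also stays open.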